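The compounds below may be only part of what the source reports. "The series", "measured", "known", "first", "only" and "open" are said of these compounds alone.

Compound 1 `CCOC(=O)CCCCCOc1cccc(CN(C(=O)c2ccc(-c3cccc(-c4nnc(C)o4)c3)cc2)C(C)C)c1`: > 26000 nM
Compound 2 `CCOC(=O)CCCCCOc1cccc(CN(C(=O)c2ccc(-c3cccc(F)c3)cc2)C(C)C)c1`: > 26000 nM

In an ADME assay on HEK293 cells (Homo sapiens) for cytotoxicity, read by CellTiter-Glo and resazurin assay, with a stated time of 72 h (a lower number here means that less compound is needed, a higher number that more compound is needed for the effect), compound 1 reaches only a limit of the assay, > 26000 nM. Compound 2 likewise gives only a limit in this assay, > 26000 nM. Among the measured compounds shown here, the one step between them, a step that the two limits leave unreadable from compound 1 to compound 2, therefore cannot be read, and the one piece of evidence in hand is the limit of > 26000 nM in this assay, at which 2 of the 2 values shown sit, so neither compound shows measurable cytotoxicity within the tested range.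

Compound 3 `CCOC(=O)CCCCCOc1cccc(CN(C(=O)c2ccc(Br)cc2)C(C)C)c1` has not been measured. It differs from compound 2 by bromo in place of 3-fluorophenyl on an aromatic carbon; the 3-fluorophenyl leaves and bromo enters, para to a large group, leaving the shared core otherwise untouched. For the measured compounds named here, no measured step speaks to this change, and with both known values sitting at the limit, no direction can be read for it.

Compound 3 is accordingly expected to stay near the same limit in this assay, at an estimated 30000 nM (range 15000 nM to 80000 nM), which would mean an expected step that the limit leaves unreadable from compound 2 to compound 3.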

Compound 3, half-maximal effective concentration: > 26000 nM
Compound 3: no number, only a limit; the forecaster's own chance of this, stated with the estimate: 80%; the middle value is on the limit's open side.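

In this assay compound 3 gives > 26000 nM as a limit of the assay, not a number. The steps among compound 1, compound 2 and compound 3 therefore cannot be read: the limit of > 26000 nM in this assay, at which 3 of the 3 values shown sit. The compounds shown leave open whether any of the three has a measurable effect in this assay and how these changes would alter it.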